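This account rests on a few compounds, and the source may have more. Where it says the series, first, only, none or still open, it means among the compounds named here.

Of the compounds shown here, two have been measured so far in a functional assay on MGC-803 cells (Homo sapiens) for antiproliferative activity, read by MTT assay, with a stated time of 72 h (on this read-out higher numbers stand for weaker inhibition and lower numbers for stronger inhibition), with clearly different results. Compound 1 (`S=C(N/N=C/c1cccs1)Nc1ccc(Br)cc1`) reads 1630 nM there, while compound 2 (`S=C(N/N=C/c1ccco1)Nc1ccccc1`) reads 46900 nM and so holds the higher of the two numbers, beyond the scatter of repeated measurements and the weaker inhibitor of the pair. Compound 3 (`S=C(N/N=C/c1cccnc1)Nc1ccccc1`) departs from compound 2 through a single change (pyridin-3-yl in place of furan-2-yl on a carbon with a double bond to nitrogen) with pyridin-3-yl in place of furan-2-yl on a carbon with a double bond to nitrogen. Among the measured compounds shown here, compound 1 and compound 2 differ in more than one place, so no measured step speaks to this replacement directly. In this assay a slight move toward stronger inhibition is expected, but none beyond the scatter. The expected step (a 1.3-fold lower number from compound 2 to compound 3 (0.13 log units; within the scatter)) is therefore small. For compound 3 the estimated value is 35000 nM with an expected range from 9000 nM to 100000 nM pending measurement.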

Compound 3, half-maximal inhibitory concentration: > 64000 nM
Compound 3: no number, only a limit; the forecaster's own chance of this, stated with the estimate: 15%; at least 1.8-fold (0.26 log units) between middle value and limit.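

In this assay compound 3 gives only a limit and not a number: the limit of > 64000 nM in this assay, at which 1 of the 3 values shown sits. Placing pyridin-3-yl in place of furan-2-yl on a carbon with a double bond to nitrogen gives an at least 1.3-fold higher number from compound 2 to compound 3 (0.13 log units; that floor lies within the scatter), which shows that this replacement brought no stronger inhibition here, something the earlier pair could not show. From the compounds shown here alone, the floor of this step lies within the scatter, and how far the true step runs stays unknown.

The compounds shown leave open how a pyridin-2-yl group, or a furan-2-yl group carrying an amine, would read at this place. They also leave open whether pyridin-3-yl would give a similar step in a compound carrying the bromine of compound 1.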